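Deglycosylation of a macrocyclic NF-kappa-B inhibitor: compound 1 to 3

The source may hold more compounds than are shown below. What is called first, only, known or untested is meant among the compounds shown, and "the series" means these compounds.

Measured so far:
compound 1 `COc1ccc(C[C@H]2C(=O)N[C@@H](C)C(=O)N(C)[C@H]3Cc4cccc(c4)Oc4cc(ccc4O[C@H]4O[C@H](CO)[C@@H](O)[C@H](O)[C@H]4O)C[C@H](C(=O)N[C@H](C)C(=O)N[C@@H](C)C(=O)N2C)N(C)C3=O)cc1` — 1850 nM
compound 2 `c1ccc2c(c1)CCN(c1ccnc(Nc3ccc(Oc4ncnc5sccc45)cc3)n1)C2` — "not determined" (no result reported)

Among the compounds with values here, compound 1 carries the only number in an assay on HEK293T cells for inhibition of nuclear factor NF-kappa-B complex (Homo sapiens), read by a luciferase reporter, with stated times of 6 h and 8 h; a higher number here means a weaker inhibitor, a lower number a stronger inhibitor; in this assay compound 1 gives 1850 nM. Compound 2 belongs to a different chemotype, and in this assay compound 2 has "not determined" (no result reported), so it offers no comparison and no pattern can be drawn from the pair.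

The next entry is compound 3 `COc1ccc(C[C@H]2C(=O)N[C@@H](C)C(=O)N(C)[C@H]3Cc4cccc(c4)Oc4cc(ccc4O)C[C@H](C(=O)N[C@H](C)C(=O)N[C@@H](C)C(=O)N2C)N(C)C3=O)cc1`, which differs from compound 1 in one place: hydrogen in place of 3,4,5-trihydroxy-6-(hydroxymethyl)oxan-2-yl on an oxygen on an aromatic ring. The aglycone thus keeps the whole shared core and exposes a hydroxy where the sugar stood.

Within the data shown here, no step between measured compounds is available to calibrate this change. With only compound 1 as anchor, the step from compound 1 to compound 3 is expected to be modest and toward stronger inhibition, a 3.1-fold lower number from compound 1 to compound 3 (0.49 log units; beyond the scatter), though a result within the scatter would not be surprising. Compound 3 is therefore estimated at 600 nM in this assay, with a plausible range from 150 nM to 3000 nM.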

Compound 3, half-maximal inhibitory concentration: 65 nM
Beside the measured number, compound 3's estimate is 9.2-fold (0.97 log units) above it; measured number below the stated range.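

In this assay, the oxygen on an aromatic ring is a position where the substituent strongly affects the read-out: hydrogen in place of 3,4,5-trihydroxy-6-(hydroxymethyl)oxan-2-yl gives a 28-fold lower number from compound 1 to compound 3 (1.45 log units; beyond the scatter). The sugar is therefore not needed for inhibition in this assay, and the shared core with a free hydroxy at this position is the stronger of the two compounds by a margin well beyond the scatter. Nothing available explains the size of this gain.

Within the data shown here, the single pair cannot separate the loss of the sugar from the gain of the free hydroxy, and it does not show how much of the activity of compound 3, at 65 nM, depends on the hydrogen on that oxygen. A methyl group or an acetyl group on the same oxygen would address that question, while a comparison between a smaller sugar such as a pentose and the 3,4,5-trihydroxy-6-(hydroxymethyl)oxan-2-yl group would show whether the size of the step tracks the size of the sugar.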